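A Ring-Opening Swap at the Amide-Type Nitrogen

A few compounds are considered here, and "the series" means these few. Any claim that something is new, unique, unknown or untested is made for them only; others in the source may bear on it.

Measured in an assay on BaF3 cells for inhibition of thrombopoietin receptor (Homo sapiens); on this read-out lower numbers stand for an effect already at smaller amounts and higher numbers for an effect only at larger amounts of compound:
- compound 1 `CC1=NN(c2ccc3c(c2)CCC3)C(=O)/C1=C(/C)NNC(=O)N1CCc2cc(C(=O)O)ccc21`: 46 nM
- compound 2 `CC1=NN(c2ccc3c(c2)CCC3)C(=O)/C1=C(/C)NNC(=S)N1CCCc2cc(C(=O)O)ccc21`: 35 nM

Among the measured compounds shown here, compound 2 shows the lower of the two numbers in this assay, yet its only neighbour, compound 1, sits within the usual scatter of it, so the two cannot be put in order. The two compounds also differ in more than one place, so no single step can be read from them.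

Compound 3 `CC1=NN(c2ccc(C)c(C)c2)C(=O)/C1=C(/C)NNC(=S)N1CCCc2cc(C(=O)O)ccc21` is not yet measured. It differs from compound 2 in one place: 3,4-dimethylphenyl in place of 2,3-dihydro-1H-inden-5-yl on an amide-type nitrogen in a ring. For the measured compounds named here, the group that leaves and the group that enters are both built from carbon only, have nearly the same count of heavy atoms and carry neither donors nor acceptors; the only change is that a fused five-membered ring is replaced by two methyl groups on the same aromatic ring. Going by the values given here, with no measured step of this kind available, the expected step from compound 2 to compound 3 is a 1.3-fold higher number from compound 2 to compound 3 (0.11 log units; within the scatter), which means none beyond the scatter. Compound 3 is therefore estimated at 45 nM, with a range from 15 nM to 150 nM.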

Compound 3, half-maximal effective concentration: 64 nM
Beside the measured number, compound 3's estimate is 1.4-fold (0.15 log units) below it, within the range that was stated.
By their numbers in this assay, from the lowest: compounds 2, 1 and 3 (each within the scatter of the next).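

Among the compounds shown here, the swap on the amide-type nitrogen provides the first single step that can be read: in this assay, 3,4-dimethylphenyl in place of 2,3-dihydro-1H-inden-5-yl gives a 1.8-fold higher number from compound 2 to compound 3 (0.26 log units; within the scatter) and so stays short of a real difference. At this position, then, the five-membered non-aromatic ring of carbon only can give way to two methyl groups on the same aromatic ring, with 8 heavy atoms in place of 9, and the read-out does not separate the two groups. Nothing measured here bears on why the two groups read alike.

The compounds shown leave open whether this position accepts groups that are not built from carbon only, such as an amine or a carboxylic acid on the aromatic ring, or a longer chain such as propyl in place of the methyl groups. They also leave open whether the same swap would read alike on the core of compound 1, which carries a carbonyl and a smaller ring at the other end of the molecule.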